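Adding a dimethylaminomethyl group to compound 2

A few compounds are considered here, and "the series" means these few. Any claim that something is new, unique, unknown or untested is made for them only; others in the source may bear on it.

Compound 1 `CN(C)CCN(C)S(=O)(=O)c1ccc2c(c1)/C(=C1/Nc3ccccc3/C1=N\O)C(=O)N2`: 18 ug/mL
Compound 2 `C=CCC1(O)/C(=C2/C(=O)Nc3ccc(S(=O)(=O)N(C)C)cc32)Nc2ccccc21`: 31 ug/mL

In a physicochemical assay for solubility, in phosphate buffer, measured as kinetic solubility, at pH 7.4 (on this read-out lower numbers stand for lower solubility and higher numbers for higher solubility), compound 2 gives 31 ug/mL, which lies within the usual scatter of compound 1 at 18 ug/mL. Compound 3 `C=CCC1(O)/C(=C2/C(=O)Nc3ccc(S(=O)(=O)N(C)CCN(C)C)cc32)Nc2ccccc21` has not yet been measured. Its structure differs from that of compound 2 by (dimethylamino)methyl in place of hydrogen on a saturated chain carbon bound to a sulfonamide nitrogen, which turns dimethylsulfamoyl into (2-(dimethylamino)ethyl)(methyl)sulfamoyl. Compound 1 also carries (2-(dimethylamino)ethyl)(methyl)sulfamoyl, on a different core, and gives 18 ug/mL. Within the data shown here, no measured pair isolates this change, so the evidence for its size is thin. A small upward change, not clearly beyond the scatter, is expected, with the estimated step being a 1.3-fold higher number from compound 2 to compound 3 (0.11 log units; within the scatter). The expected value for compound 3 is 40 ug/mL, with an estimated range of 14 ug/mL to 110 ug/mL.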

Compound 3, solubility: > 40 ug/mL
Compound 3 gave a limit, no number; the forecaster's own chance of this, stated with the estimate: 3%; the middle value sits exactly at the limit.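

Among these compounds, this is the first pair that isolates the change, since the earlier compounds offered none. In this assay, compound 3 gives a limit of the assay and not a number, and the reading stops there: the limit of > 40 ug/mL in this assay, at which 1 of the 3 values shown sits.

Putting (dimethylamino)methyl in place of hydrogen on a saturated chain carbon bound to a sulfonamide nitrogen gives an at least 1.2-fold higher number from compound 2 to compound 3 (0.11 log units; that floor lies within the scatter). The pair therefore sets only a floor on the step, and that floor does not establish a change beyond the scatter.

The compounds shown leave open how large the step really is, and whether it goes beyond the scatter. They also do not say how a longer chain ending in the same dimethylamino group, a morpholine or a carboxylic acid would read at this place.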